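From chloro to methoxy on the shared core

The source may report more compounds than this note shows. Statements on the series, on what has been measured and on what is new or still open speak of the compounds shown alone.

- Compound 1 `N#C/C(=C/c1ccc2ccccc2c1)C(=O)c1ccc[nH]1` gives < 10000 nM as a limit of the assay
- Compound 2 `Cc1ccc(/C=C(/C#N)C(=O)c2ccc[nH]2)cc1` gives 20000 nM
- Compound 3 `N#C/C(=C/c1ccc(Cl)cc1)C(=O)c1ccc[nH]1` gives 53000 nM

All three compounds were tested in a functional assay on SJ-G2 cells (Homo sapiens) for cytotoxicity, read by MTT assay, with a stated time of 72 h (a lower number here means a stronger inhibitor of growth, a higher number a weaker inhibitor of growth), and compound 1 stands there only as a limit. Of the two actual numbers, compound 3 holds the higher with 53000 nM as its value, and compound 2 is its nearest neighbour. Compound 4 `COc1ccc(/C=C(/C#N)C(=O)c2ccc[nH]2)cc1` differs from compound 3 as methoxy in place of chloro on an aromatic carbon shows, with methoxy in place of chloro on an aromatic carbon. For the measured compounds named here, one measured step bears on this change, the modest 2.7-fold higher number from compound 2 to compound 3 (0.42 log units; beyond the scatter) on putting chloro in place of methyl. Methoxy itself has no measured value yet, so a step of similar size towards a lower number is expected in this assay as chloro leaves. The estimated change is a 2.1-fold lower number from compound 3 to compound 4 (0.33 log units; beyond the scatter) in that direction. For compound 4 the estimated value is 25000 nM with a range from 9000 nM to 60000 nM as the expected span.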

Compound 4, concentration for 50% growth inhibition: < 10000 nM
Compound 4: only a limit was reported; the forecaster's own chance of this, stated with the estimate: 10%; middle value at least 2.5-fold (0.39 log units) away from the limit.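

In this assay, on an aromatic carbon para to a large group, the change shows an at least 5.3-fold lower number from compound 3 to compound 4 (0.72 log units; beyond the scatter) as methoxy replaces chloro, so a group other than methyl also gives a lower number than chloro here. Against methyl, an at least 2.0-fold lower number from compound 2 to compound 4 (0.30 log units; that floor lies within the scatter) does not tell methoxy and methyl apart, as that floor lies within the scatter. Compound 4 stands only as a limit, so both steps are floors: the limit of < 10000 nM in this assay, at which 2 of the 4 values shown sit.

Going by these compounds, how far past that limit compound 4 truly lies stays open. So does whether an amine or a carboxylic acid at this place would also give a lower number than chloro.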